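Removing the amide acyl group from an HDAC6 hydroxamic acid

The source may hold more compounds than are shown below. What is called first, only, known or untested is meant among the compounds shown, and "the series" means these compounds.

Measured so far:
compound 1, `O=C(NO)c1ccc(CN(Cc2nnnn2C2CCCCC2)C(=O)c2ccccc2)cc1`, 70 nM
compound 2, `Cc1cc(C)cc(C(=O)N(Cc2ccc(C(=O)NO)cc2)Cc2nnnn2Cc2ccccc2)c1`, 80 nM

Both compounds were tested in an assay on isolated protein for inhibition of protein deacetylase HDAC6 (Homo sapiens), read by fluorescence, with a stated time of 90 min; on this read-out lower numbers stand for stronger inhibition and higher numbers for weaker inhibition. Compound 1 gives 70 nM and compound 2 gives 80 nM. Compound 2 has the higher of the two numbers, but its nearest neighbour, compound 1, lies within the usual scatter of it, so the two cannot be told apart on these data.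

Compound 3, `O=C(NO)c1ccc(CNCc2nnnn2Cc2ccccc2)cc1`, has not yet been measured. It differs from compound 2 in one place: hydrogen in place of (3,5-dimethylphenyl)carbonyl on an amine nitrogen. The amide nitrogen of compound 2 thus becomes a plain secondary amine carrying two saturated chain carbons. For the measured compounds named here, no measured pair shows this kind of step, so its size is open. Because compound 2 gives 80 nM with the acyl group in place, its loss is expected to weaken inhibition by a step of a 3.8-fold higher number from compound 2 to compound 3 (0.57 log units; beyond the scatter). Compound 3 is therefore estimated at 300 nM, within 100 nM to 1500 nM.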

Compound 3, half-maximal inhibitory concentration: 100 nM
Estimate against measurement, compound 3: 3.0-fold (0.48 log units) above; the measured number falls inside the stated range.
By their numbers in this assay, from the lowest: compounds 1, 2 and 3 (each within the scatter of the next).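

In this assay, putting hydrogen in place of (3,5-dimethylphenyl)carbonyl on this amine nitrogen amounts to a 1.3-fold higher number from compound 2 to compound 3 (0.10 log units; within the scatter) and so leaves the two compounds indistinguishable. For the compounds shown here, the whole group, aromatic ring and carbonyl included, can therefore leave this nitrogen with no difference this read-out can detect, something the earlier compounds could not show, as both carry an acyl group there. No measurement at hand accounts for this result.

As far as these compounds go, whether a small acyl group such as acetyl, or a plain alkyl group such as methyl, on this nitrogen would also give a number within the scatter of these values remains open. Also open, from the compounds shown here alone, is whether hydrogen on this nitrogen gives the same outcome when the cyclohexyl group of compound 1 is present.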